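The compounds below may be only part of what the source reports. "The series", "measured", "known", "first", "only" and "open" are said of these compounds alone.

Working notes on the series

Compound 1 `CC(C)(C)OC(=O)NCCCCNC(=O)COn1nnc2ccccc21` carries the shared core with a single protected chain. In a toxicity assay (RAW264.7 cells) for inhibition, with Mus musculus as the target, read by resazurin assay, with a stated time of 72 h (a lower number here means that less compound is tolerated, a higher number that more compound is tolerated), compound 1 gives > 100000 nM, which is a limit of the assay rather than a number. Compound 3 `CC(C)(C)OC(=O)NCCCCN(CCCNC(=O)COn1nnc2ccccc21)C(=O)OC(C)(C)C` is also measured in this assay and gives > 100000 nM, again a limit of the assay and not a number. How the core of compound 1 and the core of compound 3 differ is not broken down here. Compound 2 `CC(C)(C)OC(=O)NCCCN(CCCCN(CCCNC(=O)COn1nnc2ccccc21)C(=O)OC(C)(C)C)C(=O)OC(C)(C)C` adds a third protected chain to compound 3 through (3-((tert-butoxycarbonyl)amino)propyl in place of hydrogen on an amide-type nitrogen), and in this assay compound 2 gives 37400 nM; the step is an at least 2.6-fold lower number from compound 3 to compound 2 (0.42 log units; beyond the scatter), which is set against the limit of > 100000 nM in this assay, at which 2 of the 3 values shown sit, rather than against a measured number.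

Compound 4 `CC(C)(C)OC(=O)NCCCN(CCCCNC(=O)COn1nnc2ccccc21)C(=O)OC(C)(C)C` is not yet measured. It stands to compound 1 as compound 2 stands to compound 3, through (3-((tert-butoxycarbonyl)amino)propyl in place of hydrogen on an amide-type nitrogen). The surroundings of the changed nitrogen read the same in both cases, so the change is of the same kind in the two pairs.

For compound 4 in this assay the expected step is an at least 1.6-fold lower number from compound 1 to compound 4 (0.22 log units; that floor lies within the scatter), an expectation that rests on an at least 2.6-fold lower number from compound 3 to compound 2 (0.42 log units; beyond the scatter) and on the limit of compound 1 at > 100000 nM. Compound 4 is thus estimated at 60000 nM, with an expected range from 25000 nM to 150000 nM.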

Compound 4, half-maximal cytotoxic concentration: > 100000 nM
Compound 4 was reported as a limit; the forecaster's own chance of this, stated with the estimate: 40%; middle value at least 1.6-fold (0.22 log units) away from the limit.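

Compound 4 gives > 100000 nM in this assay, a limit of the assay and not a number. Compound 1 is also held at a limit, so no step can be read between compound 1 and compound 4, because neither side is a measured number: the limit of > 100000 nM in this assay, at which 3 of the 4 values shown sit.

The compounds shown leave open whether 3-((tert-butoxycarbonyl)amino)propyl in place of hydrogen on this amide-type nitrogen changes the tolerated concentration on the core of compound 1.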